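Replacing hydroxymethyl with an oxadiazole in compound 3

The source may report more compounds than this note shows. Statements on the series, on what has been measured and on what is new or still open speak of the compounds shown alone.

In an ADME assay on HEp-2 cells (Homo sapiens) for cytotoxicity (a higher number here means that more compound is tolerated, a lower number that less compound is tolerated), compound 3 `CC(C)CCn1c(Cn2c(=O)n(C(C)C)c3ccccc32)nc2cc(CO)ccc21` gives 31600 nM and compound 1 `CC(C)CCn1c(Cn2c(=O)n(C(C)C)c3ccccc32)nc2cc(CNS(C)(=O)=O)ccc21` gives 30800 nM, values within the scatter of each other, while compound 2 `CC(C)CCn1c(Cn2c(=O)n(C(C)C)c3ccccc32)nc2cc(C(C)(C)N)ccc21` gives 3270 nM. Compound 4 `CC(C)CCn1c(Cn2c(=O)n(C(C)C)c3ccccc32)nc2cc(-c3ncon3)ccc21` carries 1,2,4-oxadiazol-3-yl in place of hydroxymethyl on an aromatic carbon. Among the measured compounds shown here, two measured steps bear on this change. The first, a 1.0-fold higher number from compound 1 to compound 3 (0.01 log units; within the scatter), stays within the scatter, whereas the second, a 9.7-fold higher number from compound 2 to compound 3 (0.99 log units; beyond the scatter), goes beyond it and involves 1-amino-1-methylethyl, a group absent from compound 4. Neither step introduces a ring, so the guidance is indirect, and no step beyond the scatter is expected. The expected change is a 1.4-fold lower number from compound 3 to compound 4 (0.16 log units; within the scatter). Compound 4 is estimated at 22000 nM, with an expected range of 8000 nM to 50000 nM.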

Compound 4, half-maximal cytotoxic concentration: 223000 nM
Compound 4: middle estimate off by 10-fold (1.01 log units), on the low side; measured number outside the range, above it.
By their numbers in this assay, from the lowest: compound 2; then compounds 1 and 3 (each within the scatter of the next); then compound 4.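

In this assay, this aromatic carbon proves able to carry a group that lifts the number clear of everything seen before, with 1,2,4-oxadiazol-3-yl giving a 7.1-fold higher number from compound 3 to compound 4 (0.85 log units; beyond the scatter) and a 7.2-fold higher number from compound 1 to compound 4 (0.86 log units; beyond the scatter), and the widest gap being a 68-fold higher number from compound 2 to compound 4 (1.83 log units; beyond the scatter). Until now, the hydroxymethyl and (methanesulfonamido)methyl compounds had marked the top of the range, and no ring had stood at this place. Nothing available explains why the ring raises the number. The compounds shown leave open whether this rise belongs to 1,2,4-oxadiazol-3-yl in particular or would also come with a phenyl ring or a 1,3,4-oxadiazol-2-yl group at the same carbon.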